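The source may report more compounds than this note shows. Statements on the series, on what has been measured and on what is new or still open speak of the compounds shown alone.

Compound 1 `C=CC1=C(C(=O)O)C(c2ccc(F)cc2)OC1` carries a free acid on the shared core. In a functional assay on HeLa cells (Homo sapiens) for cytotoxicity, read by MTT assay, with a stated time of 24 h (on this read-out lower numbers stand for stronger inhibition and higher numbers for weaker inhibition), compound 1 gives 67400 nM. Compound 2 `C=CC1=C(C(=O)NCc2ccccc2F)C(c2ccc(F)cc2)OC1` bears a 2-fluorobenzyl amide in place of that acid. In this assay compound 2 gives only a limit, > 100000 nM. Compound 3 `C=CC1=C(C(=O)NC2CCCCC2)C(c2ccc(F)cc2)OC1` is the cyclohexyl amide. In this assay compound 3 likewise reaches only a limit, > 100000 nM. Compound 3 thus stands at the limit of > 100000 nM in this assay, at which 2 of the 3 values shown sit. The step of an at least 1.4-fold higher number from compound 1 to compound 3 (0.17 log units; that floor lies within the scatter) is the only one with a readable floor, and that floor lies within the scatter; the step that the two limits leave unreadable from compound 2 to compound 3 cannot be read, since both of its ends are limits.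

Compound 4 `C=CC1=C(C(=O)Nc2cccc(C)c2)C(c2ccc(F)cc2)OC1` differs from compound 3 by 3-methylphenyl in place of cyclohexyl on an amide-type nitrogen. Going by the values given here, no measured step exchanges a saturated ring for an aromatic one on this nitrogen. Both amides already measured, compound 2 and compound 3, sit at the limit, while compound 1 gives a number rather than a limit. Compound 4 is therefore expected to remain at the limit, with the step that the limit leaves unreadable from compound 3 to compound 4 expected to be small or unreadable. Compound 4 is estimated at 150000 nM in this assay, within 60000 nM to 400000 nM.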

Compound 4, half-maximal inhibitory concentration: "not active" (no number reported)
For compound 4 the study gives words and no number; the estimate stays without a comparison.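

In this assay compound 4 is reported only in words, as "not active", with no number, so no new step can be read from compound 3 to compound 4. The compounds shown leave open how far compound 2, compound 3 and compound 4 lie from compound 1, and whether the group on the amide-type nitrogen changes the read-out at all.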